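Piperidinyl Gives Way to (2-Chlorophenyl)amino on the Core

A few compounds are considered here, and "the series" means these few. Any claim that something is new, unique, unknown or untested is made for them only; others in the source may bear on it.

Within the data shown here, compound 1 `CCCCCCCCCCCCNc1nc(SCc2ccc(C(F)(F)F)cc2)nc2ccccc12` is the one compound here with a number: in a functional assay on HGC-27 cells (Homo sapiens) for cytotoxicity, read by MTT assay, with a stated time of 72 h (a lower number here means a stronger inhibitor, a higher number a weaker inhibitor), compound 1 gives 38700 nM. Compound 2 `FC(F)(F)c1ccc(CSc2nc(N3CCCCC3)c3ccccc3n2)cc1` stands apart. In this assay compound 2 returns > 50000 nM, which is a limit of the assay and not a number, so compound 2 sits at the limit of > 50000 nM in this assay, at which 1 of the 2 values shown sits. Compound 3 `FC(F)(F)c1ccc(CSc2nc(Nc3ccccc3Cl)c3ccccc3n2)cc1` carries (2-chlorophenyl)amino in place of piperidin-1-yl on an aromatic carbon. Among the measured compounds shown here, no step between measured compounds is at hand, so the size of this change is open. Compound 3 is expected to land near 20000 nM, between 5000 nM and 50000 nM. That estimate implies an expected step of an at least 2.5-fold lower number from compound 2 to compound 3 (0.39 log units; beyond the scatter), a modest gain beyond the scatter.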

Compound 3, half-maximal inhibitory concentration: > 50000 nM
Compound 3: a limit, no number; the forecaster's own chance of this, stated with the estimate: 35%; middle value at least 2.5-fold (0.39 log units) away from the limit.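

Compound 2 and compound 3 both end at a limit of the assay and not at a number, so no step between them can be read: the limit of > 50000 nM in this assay, at which 2 of the 3 values shown sit.

On these data alone, whether piperidin-1-yl or (2-chlorophenyl)amino on the shared core gives the lower number in this assay stays open.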